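Second bromo on the aromatic amide of compound 2

The source may hold more compounds than are shown below. What is called first, only, known or untested is meant among the compounds shown, and "the series" means these compounds.

Compound 1 `Nc1nc2c(s1)C[C@@H](NC(=O)c1ccc[nH]1)CC2` is the parent of the pair. In an assay with sodium channel protein type 3 subunit alpha (Homo sapiens) as the target, read by patch clamp (a lower number here means a stronger inhibitor, a higher number a weaker inhibitor), compound 1 gives a limit, > 30000 nM, and this is the limit of > 30000 nM in this assay, at which 1 of the 2 values shown sits. For the measured compounds named here, compound 2 `Nc1nc2c(s1)C[C@@H](NC(=O)c1cc(Br)c[nH]1)CC2` carries bromo in place of hydrogen on an aromatic carbon; in this assay compound 2 gives 26000 nM, the only number among the values shown. The measured step of an at least 1.1-fold lower number from compound 1 to compound 2 (0.06 log units; that floor lies within the scatter) therefore reaches only to a floor that lies within the scatter.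

Compound 3 `Nc1nc2c(s1)C[C@@H](NC(=O)c1cc(Br)c(Br)[nH]1)CC2` differs from compound 2 by bromo in place of hydrogen on an aromatic carbon. Going by the values given here, the one measured step that bears on this change, an at least 1.1-fold lower number from compound 1 to compound 2 (0.06 log units; that floor lies within the scatter), was the same kind of change and did not rise beyond the scatter. For compound 3 no step beyond the scatter is expected in this assay, with a slight lean toward a lower number. The expected step is a 1.7-fold lower number from compound 2 to compound 3 (0.24 log units; within the scatter). Compound 3 is estimated at 15000 nM, between 5000 nM and 45000 nM.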

Compound 3, half-maximal inhibitory concentration: 26000 nM
Compound 3: the middle estimate sits 1.7-fold (0.24 log units) below what was measured; the range from low to high includes it.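

At the aromatic carbon next to the ring nitrogen, bromo in place of hydrogen gives no change at the digits printed from compound 2 to compound 3 (within the scatter) in this assay, so a second bromo at this position brings no readable gain or loss. Unlike the earlier step of the same kind, this one has a measured number at both ends, which makes it the first direct reading of this change in the series. Compound 1 remains a limit, so the size of the first bromo step stays unknown: the limit of > 30000 nM in this assay, at which 1 of the 3 values shown sits.

The compounds shown leave open whether a group other than bromo at this position, such as an amine, a carboxylic acid or a longer chain, would move the number in this assay. Equally open, as far as these compounds go, is what a lone bromo next to the ring nitrogen would give, without the bromo already present in compound 2.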